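Swapping a sulfonamide-bearing chain for a basic amine chain

A few compounds are considered here, and "the series" means these few. Any claim that something is new, unique, unknown or untested is made for them only; others in the source may bear on it.

Of the compounds shown here, three share a common core and have been tested in a functional assay on the whole organism with Rattus norvegicus as the target; on this read-out higher numbers stand for an effect only at larger amounts of compound and lower numbers for an effect already at smaller amounts. Compound 1, `CCCCCCCc1ccc2nc(N)sc2c1`, carries a long saturated chain on the core; in this assay compound 1 reaches only a limit, > 10 mg/kg, so no number is known for it. Compound 2, `Nc1nc2ccc(OC(F)(F)C(F)F)cc2s1`, gives 8.5 mg/kg in this assay. Compound 3, `CNS(=O)(=O)CCn1c(=N)sc2cc(OC(F)(F)F)ccc21`, gives 4 mg/kg in this assay and so stands at the lowest of the two numbers recorded; the nearest is compound 2, whose value lies beyond the usual scatter above that of compound 3.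

Compound 4, `CN(C)CCCn1c(=N)sc2cc(OC(F)(F)F)ccc21`, has not yet been measured. It differs from compound 3 in one place: (dimethylamino)methyl in place of methylsulfamoyl on a saturated chain carbon, two bonds along the chain from an aromatic nitrogen. Among the compounds with values here, no pair among the measured compounds shows this kind of exchange, so there is no measured step to lean on. The expectation for the step in this assay is therefore cautious: the change from compound 3 to compound 4 is expected to amount to a 1.1-fold higher number from compound 3 to compound 4 (0.05 log units; within the scatter), a shift that stays within the usual scatter. On that basis compound 4 is estimated to give 4.5 mg/kg in this assay, with a likely range from 1.5 mg/kg to 12 mg/kg.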

Compound 4, dose for half-maximal effect: 9 mg/kg
For compound 4 the middle estimate is 2.0-fold (0.30 log units) below the measured one; the measured number falls inside the stated range.
By their numbers in this assay, from the lowest: compound 3; then compounds 2 and 4 (each within the scatter of the next). At a limit, above all of these: compound 1.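

Within the data shown here, this is the only measured exchange at this position, and it shows that the group at the end of the chain on the shared core affects the read-out: replacing methylsulfamoyl with (dimethylamino)methyl gives a 2.3-fold higher number from compound 3 to compound 4 (0.35 log units; beyond the scatter) in this assay. The step is modest, but it means that, of these two chains, the 2-(methylsulfamoyl)ethyl chain of compound 3 acts at the smaller dose. The counted differences are clear, with one hydrogen-bond donor and two acceptors leaving and no donor and one acceptor entering, yet this single pair cannot show which difference, if any, matters, since the chain end and the chain length change together.

On these data alone, what remains open is whether the end group or the length of the chain drives the step, and a 3-(methylsulfamoyl)propyl chain, a 2-(dimethylamino)ethyl chain or a carboxylic acid at the chain end would help to separate these. Compound 1 offers no number for comparison, only a limit: the limit of > 10 mg/kg in this assay, at which 1 of the 4 values shown sits.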